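The source may report more compounds than this note shows. Statements on the series, on what has been measured and on what is new or still open speak of the compounds shown alone.

Of the compounds shown here, three sharing one core have been tested in a functional assay on the whole organism (strain Sprague-Dawley) for inhibition, with Rattus norvegicus as the target, read by paw edema, with stated times of 30 min and 2 h, at a dose of 80 mg/kg by the oral route; on this read-out lower numbers stand for less inhibition and higher numbers for more inhibition at the one dose given (going by the name of the read-out). Compound 1, with the structure `Cc1nc2ccccc2c(=O)n1NC(=O)NC1CCCCC1`, gives 41.9%. Compound 2, with the structure `CC(=O)Nc1ccc(S(=O)(=O)Nn2c(C)nc3ccccc3c2=O)cc1`, gives 37.4%. Compound 3, with the structure `O=C(NC1CCCCC1)Nn1c(CO[N+](=O)[O-])nc2ccccc2c1=O`, gives 18.7%. Compounds 1 and 2 differ at the side attached to the shared core, and the difference between these two cores is not broken down here; their values in this assay lie within the scatter of each other, so no order between them can be claimed.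

Compound 3 comes from compound 1 through one change: nitrooxy in place of hydrogen on a saturated chain carbon bound to an aromatic carbon. That change made the step of a number 23.2 percentage points lower from compound 1 to compound 3 (beyond the scatter), which is beyond the scatter and counts as modest.

Compound 4, with the structure `CC(=O)Nc1ccc(S(=O)(=O)Nn2c(CO[N+](=O)[O-])nc3ccccc3c2=O)cc1`, has not yet been measured. Among the compounds with values here, it comes from compound 2 through (nitrooxy in place of hydrogen on a saturated chain carbon bound to an aromatic carbon), the same change as the one between compound 1 and compound 3, at the same place. Within the data shown here, with only one measured example of this change, the expectation for compound 4 in this assay rests on compound 1 and compound 3 and the step of a number 23.2 percentage points lower from compound 1 to compound 3 (beyond the scatter). The step from compound 2 to compound 4 is therefore expected to be similar, about a number 20.4 percentage points lower from compound 2 to compound 4 (beyond the scatter), with wide uncertainty since a single pair is a thin basis. Compound 4 is estimated to give 17%, expected to lie between 5% and 31%.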

Compound 4, a percentage reported as inhibition, in the whole organism at one dose (the size of the read-out at that dose, not a potency): 40.4%
Compound 4: middle estimate off by 23.4 percentage points, on the low side; the measured number lies above the stated range.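

In this assay, putting nitrooxy in place of hydrogen on a saturated chain carbon bound to an aromatic carbon gave a number 3 percentage points higher from compound 2 to compound 4 (within the scatter), so on the core of compound 2 this change has no effect that can be told apart from ordinary scatter. Set beside the earlier step, the result shows that the effect of this change did not carry over from one core to the other in this series: the same change on two cores in this assay, a number 23.2 percentage points lower (beyond the scatter) from compound 1 to compound 3 and a number 3 percentage points higher (within the scatter) from compound 2 to compound 4, 26.2 percentage points apart, beyond the scatter of two such steps It does not show which part of the two structures is responsible for the gap, since compounds 1 and 2 differ in the side attached to the shared core and this is only one pair on each side, nor does it show what the change would do on any third core.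

The compounds shown leave open whether a different side group on the shared core, such as a simple amine or a longer chain, would behave like the side group of compound 1 or that of compound 2. They also leave open whether another group on the same carbon, such as a carboxylic acid, would depend on the core in the same way as nitrooxy.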